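Demethylating a phenol ether in two cores, cytotoxicity compared

The compounds below may be only part of what the source reports. "The series", "measured", "known", "first", "only" and "open" are said of these compounds alone.

Measured so far:
- compound 1, `Cc1cc(/C=C/c2ccc(O)cc2)[nH]n1`: 77400 nM
- compound 2, `COc1ccc(/C=C/c2cc(C)n[nH]2)cc1`: 12900 nM
- compound 3, `COc1ccc(/C=C/C(=O)CC(C)=O)cc1`: 18700 nM

These values come from an ADME assay on HEK293 cells (Homo sapiens) for cytotoxicity, read by MTT assay, with a stated time of 72 h; on this read-out higher numbers stand for weaker inhibition and lower numbers for stronger inhibition. Compound 3 sits near compound 2 in this assay, and well apart from compound 1. Compound 4, `CC(=O)CC(=O)/C=C/c1ccc(O)cc1`, is not yet measured. It differs from compound 3 by hydrogen in place of methyl on an oxygen on an aromatic ring. The same change, (hydrogen in place of methyl on an oxygen on an aromatic ring), links compound 2 to compound 1, where it gave a 6.0-fold higher number from compound 2 to compound 1 (0.78 log units; beyond the scatter). The two cores differ, and that difference is not broken down here, so the two changes are the same kind of change, not the same. Resting on the step from compound 2 to compound 1, a step of similar direction is expected, a 3.5-fold higher number from compound 3 to compound 4 (0.54 log units; beyond the scatter). Compound 4 is therefore estimated at 65000 nM, between 22000 nM and 190000 nM.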

Compound 4, half-maximal inhibitory concentration: 10300 nM
The estimate for compound 4 lay 6.3-fold (0.80 log units) above the measured number; measured number outside the range, below it.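

In this assay, the change from methoxy to hydroxy gave a 1.8-fold lower number from compound 3 to compound 4 (0.26 log units; within the scatter), so on this core its effect cannot be told apart from the scatter. The same change did not carry over from one core to the other: the same change on two cores in this assay, a 6.0-fold higher number (0.78 log units; beyond the scatter) from compound 2 to compound 1 and a 1.8-fold lower number (0.26 log units; within the scatter) from compound 3 to compound 4, 11-fold (1.04 log units) apart, beyond the scatter of two such steps. This shows that, in these four compounds, the step measured on one core was a poor guide to the step on the other, but it does not show which part of the cores makes the difference, and two pairs give no general rule.

The compounds shown leave open what a longer chain on that oxygen, such as ethyl, would do on either core. They also leave open how an amine in place of the hydroxy would compare.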